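The compounds below may be only part of what the source reports. "The series", "measured", "known", "first", "only" and "open" are said of these compounds alone.

Measured in a functional assay on HL-60 cells (Homo sapiens) for cytotoxicity, read by MTT assay, with a stated time of 72 h; on this read-out higher numbers stand for weaker inhibition and lower numbers for stronger inhibition:
compound 1 `COc1ccc(-c2c(-c3cc(Br)c(OC)c(OC)c3)ncn2C)cc1N`: 0.1 nM
compound 2 `COc1ccc(-c2c(-c3cc(Br)c(OC)c(OC)c3)ncn2C)cc1F`: 9700 nM
compound 3 `COc1cc(-c2ncoc2-c2ccc(N(C)C)cc2)cc(N)c1OC`: 0.9 nM

Of these three, compound 2 has the highest number, 9700 nM. Compound 4 `COc1ccc(-c2c(-c3cc(N)c(OC)c(OC)c3)ncn2C)cc1F` departs from compound 2 by one change, amino in place of bromo on an aromatic carbon. Among the compounds with values here, no measured step covers this exact change. The only one available, a 97000-fold higher number from compound 1 to compound 2 (4.99 log units; beyond the scatter), is large, but it concerns fluoro and amino at another place, so it bears only indirectly. Compound 4 keeps that fluoro. Compound 3, at 0.9 nM, also holds an amino group ortho to a methoxy group, on a different core. In this assay, a large step to a lower number is therefore expected, though the size is uncertain. The expected change is a 320-fold lower number from compound 2 to compound 4 (2.51 log units; beyond the scatter). For compound 4 the estimate is 30 nM, with an expected range of 1 nM to 1000 nM.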

Compound 4, half-maximal inhibitory concentration: > 10000 nM
Compound 4 ended at the assay's limit; the forecaster's own chance of this, stated with the estimate: 5%; at least 330-fold (2.52 log units) between middle value and limit.
By their numbers in this assay, from the lowest: compound 1; then compound 3; then compound 2. At a limit, above all of these: compound 4.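

Amino in place of bromo, on the carbon ortho to a methoxy group, brought no lower number in this assay with the fluoro kept: the step reads an at least 1.0-fold higher number from compound 2 to compound 4 (0.01 log units; that floor lies within the scatter). Compound 4 sits at a limit, not at a number: the limit of > 10000 nM in this assay, at which 1 of the 4 values shown sits. So an amino group at this place does not by itself give a low number, and the large step at the fluoro place does not carry over here.

Open, on these data alone, is how a hydroxyl or a chlorine would read at this place. Also open, as far as these compounds go, is whether amino in place of bromo would read the same on compound 1, which has amino instead of the fluoro.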